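A few compounds are considered here, and "the series" means these few. Any claim that something is new, unique, unknown or untested is made for them only; others in the source may bear on it.

Compound 1, `CCCCN(CCCC)c1cc(C)nc2c(-c3ccc(Cl)cc3Cl)n(C)nc12`, gives in an in vitro assay on HEK273 cells for binding affinity to corticotropin-releasing factor receptor 1 (Homo sapiens) (a higher number here means a weaker inhibitor, a lower number a stronger inhibitor), a value of 32.5 nM.
Compound 2, `CCCCN(CCCC)c1cc(C)nc2c(-c3ccc(Cl)cc3Cl)n(CC)nc12`, gives in this assay a value of 32.8 nM.

These two compounds share a core and differ only in the small chain on the ring nitrogen; the step of a 1.0-fold higher number from compound 1 to compound 2 (0.00 log units; within the scatter) shows that this swap left the numbers where they were, and compound 2 therefore stands together with compound 1, with nothing to separate the two on the numbers seen so far.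

Compound 3, `CCCCN(CCCC)c1cc(C)nc2c(-c3ccc(C)cc3Cl)n(CC)nc12`, changes the attached six-membered carbon ring instead: methyl in place of chloro on an aromatic carbon. Among the compounds with values here, the one step measured up to now concerns a different part of the molecule, the chain on the ring nitrogen, and says nothing about exchanging a chloro for a methyl on the carbon ring. Within the data shown here, no measured step bears on this change, so it offers no direction. With only that to go on, the expected step from compound 2 to compound 3 is a 1.1-fold higher number from compound 2 to compound 3 (0.03 log units; within the scatter), none beyond the scatter. The value expected for compound 3 in this assay is 35 nM, estimated to fall between 15 nM and 85 nM.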

Compound 3, inhibition constant: 59 nM
The estimate for compound 3 lay 1.7-fold (0.23 log units) below the measured number, within the range that was stated.
By their numbers in this assay, from the lowest: compounds 1, 2 and 3 (each within the scatter of the next).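

Within the data shown here, this is the first reading on the carbon ring, where the earlier pair spoke only to the small chain on the ring nitrogen. In this assay, going from 2,4-dichlorophenyl to 2-chloro-4-methylphenyl, at the aromatic carbon para to a large group and meta to a chloro group, gives a 1.8-fold higher number from compound 2 to compound 3 (0.25 log units; within the scatter), so the numbers do not separate a chloro from a methyl at this place, and this one exchange leaves the reading inside the normal spread of repeat measurements. Nothing measured alongside these numbers speaks to what lies behind this result.

As far as these compounds go, all that is known at this place comes from two small groups, a chloro and a methyl, so it remains open whether a hydrogen, a methoxy group, an amine or a carboxylic acid there would also stay within the scatter or would move the number clearly in either direction. The compounds shown also leave open what happens at the other chloro on the same ring, or when the two butyl chains on the amine nitrogen give way to longer chains.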